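This account rests on a few compounds, and the source may have more. Where it says the series, first, only, none or still open, it means among the compounds named here.

Three measured compounds share one core, seen in compound 1 `O=C(NO)c1ccc(NCc2nc(-c3cccs3)nn2-c2ccc(O)cc2)cc1`, compound 2 `O=C(NO)c1ccc(NCc2nc(-c3ccccc3)nn2-c2cccc(Cl)c2)cc1` and compound 3 `O=C(NO)c1ccc(NCc2nc(-c3ccc(F)cc3)nn2-c2ccccc2)cc1`, while compound 4 `O=C(NO)c1ccc(NCc2nc(-c3ccccc3)nn2-c2ccc(F)cc2)cc1` has not yet been tested. Within the data shown here, in a functional assay on MGC-803 cells (Homo sapiens) for antiproliferative activity, read by MTT assay, with a stated time of 72 h (on this read-out lower numbers stand for stronger inhibition and higher numbers for weaker inhibition), compound 1 gives > 20000 nM, which is a limit of the assay and not a number, the one value among the three that sits at the limit of > 20000 nM in this assay, at which 1 of the 3 values shown sits. In this assay compound 2 gives 13700 nM. Compound 3 gives 8960 nM in this assay. Of the two numbers shown, compound 2 holds the higher one, yet its gap to compound 3 lies within the usual scatter, so the two cannot be ordered. Compound 4 differs from compound 2 in a single respect: 4-fluorophenyl in place of 3-chlorophenyl on an aromatic nitrogen. Among the measured compounds shown here, no pair of measured compounds differs by exactly this change, so the step can only be anticipated. The expected step is a 1.4-fold lower number from compound 2 to compound 4 (0.14 log units; within the scatter), small and not beyond the scatter in either direction. Compound 4 is therefore estimated at 10000 nM in this assay, with a range from 4000 nM to 25000 nM.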

Compound 4, half-maximal inhibitory concentration: 10500 nM
Beside the measured number, compound 4's estimate is 1.1-fold (0.02 log units) below it, within the range that was stated.
By their numbers in this assay, from the lowest: compounds 3, 4 and 2 (each within the scatter of the next). At a limit, above all of these: compound 1.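

In this assay, among these compounds, a 1.3-fold lower number from compound 2 to compound 4 (0.12 log units; within the scatter) is the first step that can be read at this position, on an aromatic nitrogen of the five-membered ring, between two measured compounds. The 3-chlorophenyl and 4-fluorophenyl groups, each counted at 7 heavy atoms with no hydrogen-bond donors or acceptors, therefore cannot be told apart here, and no order can be given between compound 2 and compound 4. Nothing measured in the data shown bears on why these two groups read alike.

From the compounds shown here alone, the two groups differ in both the halogen and its place on the phenyl ring, so it remains open which of these matters, as a 4-chlorophenyl or 3-fluorophenyl group on the same nitrogen could show. Also open, going by these compounds, is whether an aminophenyl or a benzyl group there would give a step beyond the scatter.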